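Working notes: dimethylcarbamoyl in place of the oxazole

The source may hold more compounds than are shown below. What is called first, only, known or untested is meant among the compounds shown, and "the series" means these compounds.

Two compounds of the series have numbers in an assay on isolated protein for inhibition of 2-Hydroxyacid oxidase 1 (Homo sapiens), with stated times of 30 min and 15 min; on this read-out lower numbers stand for stronger inhibition and higher numbers for weaker inhibition. Compound 1 `CC(C)c1coc(-c2cccc(CNc3ccc4[nH]nc(C(=O)O)c4c3)c2O)n1` gives 87 nM in this assay, and compound 2 `Cc1nc(-c2cccc(CN(C)c3ccc4[nH]nc(C(=O)O)c4c3)c2)sc1C` gives 290 nM in this assay. Compound 1 has the lowest of the two numbers; the nearest is compound 2, whose number stands beyond the scatter relative to compound 1. The two differ in more than one place, so no single step can be read off between them.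

Compound 3 `CN(C)C(=O)c1cccc(CNc2ccc3[nH]nc(C(=O)O)c3c2)c1O` is not yet measured. It differs from compound 1 in one place: dimethylcarbamoyl in place of 4-isopropyl-1,3-oxazol-2-yl on an aromatic carbon. The hydroxy group and the shared core remain as in compound 1. Among the measured compounds shown here, no measured pair shows a change of this kind, so the expectation rests only on the two numbers above and is held loosely. The expected change is a 4.6-fold higher number from compound 1 to compound 3 (0.66 log units; beyond the scatter), toward a higher number and beyond the scatter, with wide uncertainty in both directions. For compound 3 the estimated value in this assay is 400 nM, with a range from 100 nM to 1600 nM.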

Compound 3, half-maximal inhibitory concentration: > 30000 nM
Compound 3 gave a limit, no number; the forecaster's own chance of this, stated with the estimate: 5%; middle value at least 75-fold (1.87 log units) away from the limit.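

In this assay compound 3 gives no number, only a limit of the assay: the limit of > 30000 nM in this assay, at which 1 of the 3 values shown sits.

Among the compounds shown here, with the hydroxy group and the shared core kept, dimethylcarbamoyl in place of 4-isopropyl-1,3-oxazol-2-yl gives an at least 340-fold higher number from compound 1 to compound 3 (2.53 log units; beyond the scatter) and this is the first single change that can be read. The position on the aromatic carbon, ortho to a hydroxy group, is therefore far from indifferent to the group it carries, which the earlier pair, differing in more than one place, could not show. The shared core and the hydroxy group alone do not keep a measurable number in this assay once the 4-isopropyl-1,3-oxazol-2-yl group has left.

The compounds shown leave open whether the five-membered aromatic ring, the isopropyl group or the count of heavy atoms carries this loss; the step changes all of them at once, and its full size stays unknown. Also open, as far as these compounds go, is how an unsubstituted 1,3-oxazol-2-yl group, a phenyl ring or a longer chain on the amide nitrogen would stand at this position.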